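The source may hold more compounds than are shown below. What is called first, only, known or untested is meant among the compounds shown, and "the series" means these compounds.

Compound 3 `Fc1ccc(C2CC(c3ccc(Cl)s3)=NN2c2nc(-c3ccccc3)cs2)cc1` carries a plain phenyl ring on the shared core. In an ADME assay on NIH3T3 cells (Mus musculus) for cytotoxicity, read by XTT assay, with a stated time of 24 h (a higher number here means a weaker inhibitor, a lower number a stronger inhibitor), compound 3 gives > 500 ug/mL, which is a limit of the assay rather than a number. Compound 1 `Fc1ccc(C2CC(c3ccc(Cl)s3)=NN2c2nc(-c3ccc(C(F)(F)F)cc3)cs2)cc1` gives > 500 ug/mL, also a limit. Compound 2 `Fc1ccc(C2CC(c3ccc(Cl)s3)=NN2c2nc(-c3ccc(Br)cc3)cs2)cc1` gives > 500 ug/mL, again a limit. Because all three values sit at the limit of > 500 ug/mL in this assay, at which 3 of the 3 values shown sit, the steps a step that the two limits leave unreadable from compound 1 to compound 2, a step that the two limits leave unreadable from compound 1 to compound 3 and a step that the two limits leave unreadable from compound 2 to compound 3 cannot be read in size. Compound 4 `Cc1ccc(-c2csc(N3N=C(c4ccc(Cl)s4)CC3c3ccc(F)cc3)n2)cc1` differs from compound 3 by methyl in place of hydrogen on an aromatic carbon, in words: methyl in place of hydrogen on an aromatic carbon. Among the measured compounds shown here, no measured step gives a readable size for a change of this kind, so no shift beyond the scatter is expected. Compound 4 is therefore expected to give 600 ug/mL, in a range from 300 ug/mL to 1500 ug/mL. This estimate means a step that the limit leaves unreadable from compound 3 to compound 4, expected to stay within the scatter.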

Compound 4, half-maximal inhibitory concentration: > 500 ug/mL
Compound 4: a limit, no number (the forecaster's own chance of this, stated with the estimate: 85%); the middle value lies beyond the limit too.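

Among the compounds shown here, no step from compound 1, compound 2 or compound 3 to compound 4 can be read in size, because all the values stand at one limit: the limit of > 500 ug/mL in this assay, at which 4 of the 4 values shown sit. The compounds shown leave open whether changing these groups alters the result in this assay at all.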